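Pyridine isomers on a shared core and growth inhibition

The compounds below may be only part of what the source reports. "The series", "measured", "known", "first", "only" and "open" are said of these compounds alone.

Compound 1 `c1ccc(-c2cc(-c3ccsc3)cc(-c3cccnc3)n2)nc1` gives > 100 ug/mL (a limit)
Compound 2 `c1ccc(-c2cc(-c3cccs3)cc(-c3ccccn3)n2)nc1` gives 0.44 ug/mL
Compound 3 `c1ccc(-c2cc(-c3cccs3)cc(-c3ccncc3)n2)nc1` gives 36.2 ug/mL

In a functional assay on A549 cells (Homo sapiens) for antiproliferative activity (on this read-out lower numbers stand for stronger inhibition of growth and higher numbers for weaker inhibition of growth), compound 3 holds the higher of the two actual numbers, at 36.2 ug/mL. Compound 1, which also carries pyridin-3-yl, gives > 100 ug/mL, and this is a limit of the assay. Compound 4 `c1ccc(-c2cc(-c3cccs3)cc(-c3cccnc3)n2)nc1` has pyridin-3-yl in place of pyridin-4-yl on an aromatic carbon. Going by the values given here, the one measured step at this place is an 82-fold higher number from compound 2 to compound 3 (1.92 log units; beyond the scatter), and it concerns pyridin-2-yl, which neither compound 3 nor compound 4 has there. No step beyond the scatter is therefore expected in this assay, and compound 4 should stay in the weak range of compound 3 at 36.2 ug/mL. The expected change is a 1.2-fold lower number from compound 3 to compound 4 (0.08 log units; within the scatter). For compound 4 the estimated value is 30 ug/mL, with an expected range from 6 ug/mL to 100 ug/mL.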

Compound 4, concentration for 50% growth inhibition: 78.9 ug/mL
Compound 4: middle estimate off by 2.6-fold (0.42 log units), on the low side; the measured number falls inside the stated range.
By their numbers in this assay, from the lowest: compound 2; then compound 3; then compound 4. At a limit, above all of these: compound 1.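

With a 2.2-fold higher number from compound 3 to compound 4 (0.34 log units; beyond the scatter), growth inhibition is weaker with pyridin-3-yl than with pyridin-4-yl, a modest step beyond the scatter in this assay, so all three pyridine isomers can be ordered with thiophen-2-yl on the shared core. Pyridin-2-yl stands far from both, with a 180-fold higher number from compound 2 to compound 4 (2.25 log units; beyond the scatter), a much larger step than the one between the other two isomers. Thiophen-2-yl in place of thiophen-3-yl comes with an at least 1.2-fold lower number from compound 1 to compound 4 (0.10 log units; that floor lies within the scatter), so no step beyond the scatter can be claimed for this change. Compound 1 stands at a limit: the limit of > 100 ug/mL in this assay, at which 1 of the 4 values shown sits.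

The compounds shown leave open whether pyridin-2-yl keeps its advantage with thiophen-3-yl on the core, and whether an amine or a methoxy group on the pyridin-2-yl ring would preserve the growth inhibition of compound 2.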